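Chain extension on the amide side chain of compound 2

A few compounds are considered here, and "the series" means these few. Any claim that something is new, unique, unknown or untested is made for them only; others in the source may bear on it.

Compound 1 `Cn1c(=O)c(C(=O)NCCN)c(O)c2ccccc21` gives 67% in a functional assay on the whole organism (strain Fischer 344) for inhibition, with Rattus norvegicus as the target, read by paw edema, at a dose of 0.01 mmol/kg by the intraperitoneal route; on this read-out lower numbers stand for less inhibition and higher numbers for more inhibition at the one dose given (going by the name of the read-out). Among the measured compounds shown here, compound 2 `NCCNC(=O)c1c(O)c2ccccc2n(-c2ccccc2)c1=O` gives 68.1% in this assay; the single measured step, a number 1.1 percentage points higher from compound 1 to compound 2 (within the scatter), lies within the scatter, so compound 2 stands alongside compound 1 without any separation in paw-edema inhibition. Compound 3 `NCCCCCCNC(=O)c1c(O)c2ccccc2n(-c2ccccc2)c1=O` is not yet measured in this assay. Against compound 2 it differs by 4-aminobutyl in place of amino on a saturated chain carbon, two bonds along the chain from an amide-type nitrogen. For the measured compounds named here, no measured step touches this part of the series: the one step on record concerns the methyl-to-phenyl exchange on the aromatic nitrogen, a different place, and it was within the scatter. There is thus no measured basis for a direction, and the step expected is a number 5.1 percentage points lower from compound 2 to compound 3 (within the scatter), most likely small against the scatter, with the range kept wide for the unmeasured change. Compound 3 is estimated at 63%, within 40% to 80%.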

Compound 3, a percentage reported as inhibition, in the whole organism at one dose (the size of the read-out at that dose, not a potency): 68.8%
For compound 3 the middle estimate is 5.8 percentage points below the measured one; the range from low to high includes it.
By their numbers in this assay, from the lowest: compounds 1, 2 and 3 (each within the scatter of the next).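

The step in this assay is a number 0.7 percentage points higher from compound 2 to compound 3 (within the scatter). Among the compounds shown here, this is the first reading on the amide side chain, and it shows that 2-aminoethyl and 6-aminohexyl, the same difference cut one bond further out, are not separated in paw-edema inhibition on the core of compound 2, with the phenyl group on the aromatic nitrogen held constant. No available evidence bears on why these two compounds stand level.

Open, from the compounds shown here alone, is whether the amino group on this chain is needed at all, which a carboxylic acid, a hydroxyl group or a dimethylamino group in its place would test, and whether a longer chain such as 8-aminooctyl still gives the same reading. A reading at one dose also leaves any separation in potency between compound 2 and compound 3 unresolved.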